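Acetate to amino-acid ester exchange on two related cores

This account rests on a few compounds, and the source may have more. Where it says the series, first, only, none or still open, it means among the compounds named here.

Measured so far:
Compound 1, `CC(C)[C@H](N)C(=O)OCCCOC1(c2ccc(Cl)cc2)c2ccccc2C(=O)N1Cc1ccc(Cl)cc1`, in a functional assay on HCT-116 cells (Homo sapiens) for inhibition, read by fluorescence, with a stated time of 48 h (a higher number here means a weaker inhibitor of growth, a lower number a stronger inhibitor of growth), gives 60000 nM.
Compound 2, `CC(=O)OCCCOC1(c2ccc(Cl)cc2)c2ccccc2C(=O)N1Cc1ccc(Cl)cc1`, in this assay gives 68000 nM.
Compound 3, `CC(=O)OCC(C)(C)COC1(c2ccc(Cl)cc2)c2ccccc2C(=O)N1Cc1ccccc1`, in this assay gives 70000 nM.

Compound 2 and compound 1 share one core and differ only by 1-amino-2-methylpropyl in place of methyl on a carbonyl carbon. The step of a 1.1-fold lower number from compound 2 to compound 1 (0.05 log units; within the scatter); the two numbers lie within the scatter of each other, so no change of potency is read from this pair. Compound 3 sits on a second core; the difference between the two cores is not broken down here. Its number and that of compound 2 are within the scatter of each other, as are its number and that of compound 1.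

Compound 4, `CC(C)[C@H](N)C(=O)OCC(C)(C)COC1(c2ccc(Cl)cc2)c2ccccc2C(=O)N1Cc1ccccc1`, is not yet measured in this assay. It differs from compound 3 by 1-amino-2-methylpropyl in place of methyl on a carbonyl carbon. The place is the same as in the pair compound 2 to compound 1, so this is the same change made on the second core. The step is expected to be a 1.1-fold lower number from compound 3 to compound 4 (0.05 log units; within the scatter), resting on the earlier pair because a 1.1-fold lower number from compound 2 to compound 1 (0.05 log units; within the scatter). Compound 4 is therefore expected to give about 63000 nM, estimated to fall between 35000 nM and 115000 nM.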

Compound 4, concentration for 50% growth inhibition: 65000 nM
Beside the measured number, compound 4's estimate is 1.0-fold (0.01 log units) below it; the measured number falls inside the stated range.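

In this assay the exchange of methyl for 1-amino-2-methylpropyl on a carbonyl carbon gives a 1.1-fold lower number from compound 3 to compound 4 (0.03 log units; within the scatter) and so no change of potency is read on the second core, the same outcome as on the first. The change carries over between these two cores as a null result, and the two steps do not differ: the same change on two cores in this assay, a 1.1-fold lower number (0.05 log units; within the scatter) from compound 2 to compound 1 and a 1.1-fold lower number (0.03 log units; within the scatter) from compound 3 to compound 4, 1.1-fold (0.02 log units) apart, within the scatter of two such steps. This does not show that a step of real size would carry over in the same way: neither step lies beyond the scatter, and two cores set no rule for the wider series.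

Left open is whether a free hydroxyl or a carboxylic acid in place of the ester, or a longer chain on the carbonyl carbon, would move the number in this assay on either core. Also open, on these data alone, is what each difference between the two cores contributes on its own.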